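Amino in Place of Hydroxy on a Double-Bonded Nitrogen

The compounds below may be only part of what the source reports. "The series", "measured", "known", "first", "only" and "open" are said of these compounds alone.

Compound 1 `N#Cc1c2n(c(=O)n(-c3ccccc3)/c1=N\CCO)CCC2`: 25.9%
Compound 2 `NC1=C(/C(N)=N\O)C2CCCN2C(=O)N1c1ccccc1`: 21.6%

Of the compounds shown here, two have been tested in a functional assay on the whole organism (strain albino) for inhibition, with Rattus norvegicus as the target, read by paw edema, with a stated time of 3 h, at a dose of 0.029 mmol/kg by the oral route; on this read-out higher numbers stand for more inhibition at the one dose given (going by the name of the read-out) and lower numbers for less inhibition. In this assay compound 1 gives 25.9%, and compound 2 gives 21.6%. Of the two numbers, compound 2 holds the lower one, but its distance to compound 1 falls within the usual scatter of repeated measurements, so the two compounds cannot be told apart on this evidence.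

Compound 3 `N/N=C(/N)C1=C(N)N(c2ccccc2)C(=O)N2CCCC12` has not yet been measured. It differs from compound 2 in a single place: amino in place of hydroxy on a double-bonded nitrogen. Going by the values given here, the measured pair does not differ in one place, so no measured step is available to show what such a change does. Nothing in the numbers points to a rise or to a fall, and the two measured compounds sit close together.

In this assay the step from compound 2 to compound 3 is expected to be a number 0.4 percentage points higher from compound 2 to compound 3 (within the scatter), which is to say no change beyond the scatter in either direction. Compound 3 is therefore estimated at 22%, with a range from 8% to 38%.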

Compound 3, a percentage reported as inhibition, in the whole organism at one dose (the size of the read-out at that dose, not a potency): 25.9%
Estimate against measurement, compound 3: 3.9 percentage points below, within the range that was stated.
By their numbers in this assay, from the lowest: compounds 2, 1 and 3 (each within the scatter of the next).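

In this assay, going by these compounds alone, the change to amino in place of hydroxy on a double-bonded nitrogen gives a number 4.3 percentage points higher from compound 2 to compound 3 (within the scatter), the first measured step at this position, and it shows that this one swap leaves the number inside the spread of repeat measurements. The result therefore gives no sign that this position responds to the exchange of these two groups, which match in their counts of heavy atoms, hydrogen-bond donors and hydrogen-bond acceptors, and neither carries a net charge. Nothing available bears on why the two groups give results that cannot be told apart.

The compounds shown leave open whether a larger group on the same nitrogen, such as methoxy or dimethylamino, would move the number beyond the scatter, so a flat result here describes only hydroxy and amino. They also leave open how the two groups compare at other doses, as a reading at one dose gives the size of an effect and not a potency.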